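The source may hold more compounds than are shown below. What is called first, only, known or untested is meant among the compounds shown, and "the series" means these compounds.

Of the compounds shown here, two with the same core have been measured in a functional assay on MDA-MB-435 cells (Homo sapiens) for cytotoxicity, read by sulforhodamine B assay, with a stated time of 48 h, tested at 0.01 uM; on this read-out lower numbers stand for a stronger effect and higher numbers for a weaker effect at the one concentration tested. Compound 1 `COc1ccc(-c2cc(/C=C/C(=O)c3ccc(N)cc3)[nH]n2)cc1` gives 97% in this assay, meaning almost none of the cells are affected at this single low concentration. Compound 2 `COc1cc(-c2cc(/C=C/C(=O)c3ccc(Cl)c(Cl)c3)[nH]n2)cc(OC)c1OC` gives 94% in this assay. Compound 2 thus stands alongside compound 1: the gap between the two numbers lies within the scatter, so neither can be called more or less active than the other, and both show hardly any effect.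

Compound 3 `COc1ccc(C(=O)/C=C/c2cc(-c3cc(OC)c(OC)c(OC)c3)n[nH]2)cc1` is not yet measured in this assay. Its difference from compound 2 is 4-methoxyphenyl in place of 3,4-dichlorophenyl on a carbonyl carbon. Among the compounds with values here, no comparable step between measured compounds is available, so nothing indicates that this swap would move the read-out beyond the scatter in either direction. The number for compound 3 is therefore expected to be 96%, between 85% and 105%, which means an expected step of a number 2 percentage points higher from compound 2 to compound 3 (within the scatter).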

Compound 3, a percentage reported as activity, at one concentration (the size of the read-out at that concentration, not a potency): 99%
For compound 3 the middle estimate is 3 percentage points below the measured one; measured number inside the range.
By their numbers in this assay, from the lowest: compounds 2, 1 and 3 (each within the scatter of the next).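

In this assay, within the data shown here, putting 4-methoxyphenyl in place of 3,4-dichlorophenyl on a carbonyl carbon gives a number 5 percentage points higher from compound 2 to compound 3 (within the scatter) and so provides the first single-place comparison in this set. At this one low concentration, the read-out does not separate a ring carrying two chlorines from a ring carrying one methoxy group, and both compounds show hardly any effect. Nothing available explains why these two groups read alike.

The compounds shown leave open whether a different kind of group on the carbonyl carbon, such as a carboxylic acid or a longer alkyl chain in place of the aromatic ring, would shift the read-out beyond the scatter. They also leave open whether compound 2 and compound 3 would still read alike at higher concentrations.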